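The source may hold more compounds than are shown below. What is called first, only, known or untested is meant among the compounds shown, and "the series" means these compounds.

Measured so far in a functional assay on HeLa cells (Homo sapiens) for inhibition, read by MTT assay, with a stated time of 72 h (a lower number here means a stronger inhibitor, a higher number a weaker inhibitor), as follows:
- compound 1 (`CC(C)C[C@H](NC(=O)CC[C@H](NC(=O)[C@H](C)NC(=O)OC(C)(C)C)C(=O)NCc1ccc2ccccc2c1)B(O)O`) gives 2350 nM as a number
- compound 2 (`CC(C)C[C@H](NC(=O)CC[C@H](NC(=O)OC(C)(C)C)C(=O)NCc1ccc2ccccc2c1)B(O)O`) gives > 10000 nM as a limit
- compound 3 (`CC(C)C[C@H](NC(=O)CCC[C@H](NC(=O)[C@H](C)NC(=O)OC(C)(C)C)C(=O)NCc1ccc2ccccc2c1)B(O)O`) gives > 10000 nM as a limit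

Among the compounds with values here, compound 1 is the only compound with a measured number, the other two standing at the limit of > 10000 nM in this assay, at which 2 of the 3 values shown sit.

Compound 4 (`CC(C)C[C@H](NC(=O)CC[C@H](NC(=O)[C@H](CC(C)C)NC(=O)OC(C)(C)C)C(=O)NCc1ccc2ccccc2c1)B(O)O`) differs from compound 1 by isopropyl in place of hydrogen on a saturated chain carbon, two bonds along the chain from an amide-type nitrogen and a carbonyl carbon in the structure. Cut one bond further out, the same difference reads methyl to isobutyl.

Within the data shown here, no measured step makes this change. The closest is an at least 4.2-fold higher number from compound 1 to compound 2 (0.62 log units; beyond the scatter) as tert-butoxy replaces 1-((tert-butoxycarbonyl)amino)ethyl, and this step touches the same part of the molecule. The other, an at least 4.2-fold higher number from compound 1 to compound 3 (0.62 log units; beyond the scatter) on a change in the chain, bears only indirectly. As far as these compounds go, both steps end at a limit, so their full size is unknown, and neither gives a direction for a larger group at this place. No step beyond the scatter is therefore expected in this assay with confidence. The expected move is a 1.6-fold lower number from compound 1 to compound 4 (0.19 log units; within the scatter) and remains uncertain. Compound 4 is estimated at 1500 nM within a range of 300 nM to 8000 nM for the expected measurement.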

Compound 4, half-maximal inhibitory concentration: 790 nM
The estimate for compound 4 lay 1.9-fold (0.28 log units) above the measured number; low and high end bracket the measured number.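

In this assay, within the data shown here, the change from methyl to isobutyl gives a 3.0-fold lower number from compound 1 to compound 4 (0.47 log units; beyond the scatter) on this saturated chain carbon, the only step between two measured numbers. The earlier steps shown here at this end of the molecule ended at limits and gave no direction for a larger group, whereas this one shows that isobutyl is accepted here, with a lower number beyond the scatter. This rests on one pair of compounds, so no trend with the size of the group can be claimed.

As far as these compounds go, whether a benzyl group or a longer chain on this carbon would lower the number further, and what an amine or a carboxylic acid would do here, remains open. Compound 2 and compound 3 give limits and not numbers, so the full size of their steps remains unknown: the limit of > 10000 nM in this assay, at which 2 of the 4 values shown sit.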